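The compounds below may be only part of what the source reports. "The series", "measured", "known", "first", "only" and "open" are said of these compounds alone.

Compounds measured in a functional assay on isolated protein for inhibition of Glucose-dependent insulinotropic receptor (Rattus norvegicus), read by HTRF and cAMP accumulation; a lower number here means a smaller maximal response, a higher number a larger maximal response:
Compound 1 `Cc1nc(S(C)(=O)=O)ccc1Oc1ncnc(OC2CCN(C(=O)OC3COC3)CC2)c1F` gives 66%.
Compound 2 `Cc1nc(S(C)(=O)=O)ccc1Oc1ncnc(OC2CCN(C(=O)SC3(C)CC3)CC2)c1F` gives 77%.

Within the data shown here, compound 2 holds the higher of the two efficacies: its only neighbour, compound 1, sits lower by a number 11 percentage points higher from compound 1 to compound 2 (beyond the scatter). The step to compound 3 `CCc1cnc(C(=O)N2CCC(Oc3ncnc(Oc4ccc(S(C)(=O)=O)nc4C)c3F)CC2)nc1` replaces the group on the carbonyl carbon once more: a group of 8 heavy atoms (6 carbon, 2 nitrogen; one six-membered aromatic ring with 2 hetero atoms) in place of a group of 5 heavy atoms (4 carbon, 1 sulfur; one three-membered non-aromatic ring of carbon only), on a carbonyl carbon. Among the measured compounds shown here, only one measured step touches this carbonyl position, the change from compound 1 to compound 2, and it moved the efficacy by a number 11 percentage points higher from compound 1 to compound 2 (beyond the scatter). That step swapped one small non-aromatic ring for another; the present change brings in an aromatic heterocycle of a different size and acceptor count, so the measured step is only a loose guide. Compound 3 is expected to remain near compound 2, with a step of a number 3 percentage points lower from compound 2 to compound 3 (within the scatter), well inside the scatter. The efficacy of compound 3 is estimated at 74%, between 58% and 90%.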

Compound 3, largest response reached (reported as efficacy), in percent of the reference or control that the assay uses: 80%
The estimate for compound 3 lay 6 percentage points below the measured number; the range from low to high includes it.
By their numbers in this assay, from the lowest: compound 1; then compounds 2 and 3 (each within the scatter of the next).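

Placing an aromatic group on this carbonyl carbon leaves the maximal response in this assay essentially unchanged from the sulfur-linked group, with 5-ethylpyrimidin-2-yl giving a number 3 percentage points higher from compound 2 to compound 3 (within the scatter), so the position accepts more than small non-aromatic rings. Set against the (oxetan-3-yl)oxy group, the same 5-ethylpyrimidin-2-yl gives a number 14 percentage points higher from compound 1 to compound 3 (beyond the scatter), which means two structurally different groups now both stand clear of compound 1, and that separation is not confined to the sulfur-containing group. Nothing at hand accounts for these differences.

On these data alone, how much of the response depends on the ethyl group remains open, as a pyrimidin-2-yl without it would show. As far as these compounds go, it is also open how a plain phenyl ring or a simple dimethylamino group would read at this carbonyl carbon.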